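Ester variation on the carbamate of compound 2

This account rests on a few compounds, and the source may have more. Where it says the series, first, only, none or still open, it means among the compounds named here.

Measured so far:
compound 1 `Cc1cc(NC(=O)C2CCCC2)nn1Cc1cc(Cl)ccc1OCc1ccccc1`: 15.9 nM
compound 2 `Cc1cc(NC(=O)OC(C)(C)C)nn1Cc1cc(Cl)ccc1OCc1ccccc1`: 25.1 nM

In an assay on CHO-K1 cells for displacement of a labelled ligand from prostaglandin E2 receptor EP1 subtype (Homo sapiens) (on this read-out higher numbers stand for weaker inhibition and lower numbers for stronger inhibition), compound 1 gives 15.9 nM and compound 2 gives 25.1 nM. Compound 2 holds the higher of the two numbers, but the step of a 1.6-fold higher number from compound 1 to compound 2 (0.20 log units; within the scatter) lies within the scatter, so the two compounds cannot be told apart on these data. Compound 3 `Cc1cc(NC(=O)OCc2ccccn2)nn1Cc1cc(Cl)ccc1OCc1ccccc1` is compound 2 with (pyridin-2-yl)methyl in place of tert-butyl on an oxygen next to a carbonyl group. Among the compounds with values here, no measured step touches this oxygen substituent; the only step in hand, a 1.6-fold higher number from compound 1 to compound 2 (0.20 log units; within the scatter), exchanges a cyclopentyl group for tert-butoxy on the carbonyl carbon and is itself within the scatter. That step gives no direction for the present change, so no shift beyond the scatter is expected, though the range is kept wide because nothing measured probes the entering (pyridin-2-yl)methyl group. The estimate for compound 3 is 30 nM, expected between 10 nM and 100 nM, which means an expected step of a 1.2-fold higher number from compound 2 to compound 3 (0.08 log units; within the scatter).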

Compound 3, half-maximal inhibitory concentration: 79.4 nM
Compound 3: the middle estimate sits 2.6-fold (0.42 log units) below what was measured, and the stated range covers the measured number.
By their numbers in this assay, from the lowest: compounds 1 and 2 (each within the scatter of the next); then compound 3.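

Within the data shown here, at the oxygen next to a carbonyl group, the carbamate substituent matters in this assay: (pyridin-2-yl)methyl in place of tert-butyl gives the first step that lies beyond the scatter (a 3.2-fold higher number from compound 2 to compound 3 (0.50 log units; beyond the scatter)). The comparison with the cyclopentyl group on the carbonyl carbon points the same way (a 5.0-fold higher number from compound 1 to compound 3 (0.70 log units; beyond the scatter)), so compound 3 separates from both neighbours, which themselves remain within the scatter of each other. No evidence at hand bears on the origin of this shift.

On these data alone, whether the step belongs to the aromatic ring, to its nitrogen or to the position of that nitrogen stays open. A benzyl group or a (pyridin-3-yl)methyl group on the same oxygen would separate these readings, and a simple methyl or ethyl group would show how much the tert-butyl branching contributes.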